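Working notes on the amine chain variants

The source may hold more compounds than are shown below. What is called first, only, known or untested is meant among the compounds shown, and "the series" means these compounds.

Measured so far:
compound 1, `COc1cc2oc(-c3ccccc3)cc(=O)c2c(O)c1OCCCN1CCCCC1`: 22300 nM in a functional assay on HepG2 cells (Homo sapiens) for antiproliferative activity, read by MTT assay, with a stated time of 48 h; a higher number here means a weaker inhibitor, a lower number a stronger inhibitor
compound 2, `COc1cc2oc(-c3ccccc3)cc(=O)c2c(O)c1OCCCCN1CCN(C)CC1`: 36700 nM in this assay

Compound 2 and compound 1 lie within the scatter of each other in this assay, as a 1.6-fold higher number from compound 1 to compound 2 (0.22 log units; within the scatter) shows. Compound 3, `CCN(CC)CCCCOc1c(OC)cc2oc(-c3ccccc3)cc(=O)c2c1O`, is not yet measured. It differs from compound 2 by diethylamino in place of 4-methylpiperazin-1-yl on a saturated chain carbon, four bonds along the chain from an oxygen on an aromatic ring. Going by the values given here, only the step from compound 1 to compound 2 bears on this, and that step stayed within the scatter, so for compound 3 no step beyond the scatter is expected in this assay. Compound 3 is expected to give about 30000 nM, between 12000 nM and 75000 nM. The expected step is a 1.2-fold lower number from compound 2 to compound 3 (0.09 log units; within the scatter).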

Compound 3, half-maximal inhibitory concentration: 7100 nM
Estimate against measurement, compound 3: 4.2-fold (0.63 log units) above, outside the stated range (below it).
By their numbers in this assay, from the lowest: compound 3; then compounds 1 and 2 (each within the scatter of the next).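

The amine at the end of the chain does register in this assay: diethylamino in place of 4-methylpiperazin-1-yl gives a step beyond the scatter (a 5.2-fold lower number from compound 2 to compound 3 (0.71 log units; beyond the scatter)), which the earlier pair did not show. Compound 3 also separates from the piperidin-1-yl compound (a 3.1-fold lower number from compound 1 to compound 3 (0.50 log units; beyond the scatter)), so among these three the open-chain amine stands apart from both ring amines. Nothing at hand explains this result.

Open, on these data alone, is whether dimethylamino or a morpholine ring would track compound 3 or compounds 1 and 2. Also open, as far as these compounds go, is whether the lower number from diethylamino persists on a longer chain.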